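A few compounds are considered here, and "the series" means these few. Any claim that something is new, unique, unknown or untested is made for them only; others in the source may bear on it.

Compound 1, `OC[C@H]1O[C@@H](n2cnc3c(NCc4ccccc4)nccc32)C[C@@H]1O`, was tested in a functional assay on the whole organism (Pleural cavity) with Rattus norvegicus as the target; a lower number here means that less compound is needed, a higher number that more compound is needed for the effect. In this assay compound 1 gives > 9 mg/kg, which is a limit of the assay and not a measured number. Compound 2, `[N-]=[N+]=Nc1nccc2c1ncn2C1O[C@H](CO)[C@@H](O)[C@H]1O`, gives > 9 mg/kg in this assay, again only a limit. Compound 3, `Clc1[nH]ccc2ncnc1-2`, gives > 9 mg/kg in this assay, also a limit. Among the compounds with values here, every result so far sits at the limit of > 9 mg/kg in this assay, at which 3 of the 3 values shown sit, so compound 1 stands nowhere in particular: no measured step separates it from compound 2 or compound 3, and none of the three can be called more or less potent than another.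

The next compound, compound 4, `CSc1nccc2c1ncn2[C@H]1C[C@H](O)[C@@H](CO)O1`, differs from compound 1 in a single place: methylsulfanyl in place of benzylamino on an aromatic carbon. Within the data shown here, since no step between measured compounds exists here, any expectation rests on the shared core alone. The step from compound 1 to compound 4 is expected to be a step that the limit leaves unreadable from compound 1 to compound 4, a change no larger than the scatter. For compound 4 the dose for half-maximal effect in this assay is estimated at 12 mg/kg, with a range from 4 mg/kg to 40 mg/kg, and the assay is expected most likely to report only a limit again.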

Compound 4, dose for half-maximal effect: > 9 mg/kg
Compound 4 gave a limit, no number (the forecaster's own chance of this, stated with the estimate: 75%); the middle value lies beyond the limit too.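

Compound 1 and compound 4 both give only a limit in this assay, so no step between them can be read: the limit of > 9 mg/kg in this assay, at which 4 of the 4 values shown sit.

The compounds shown leave open what dose of any of them gives the half-maximal effect, and whether methylsulfanyl in place of benzylamino changes that dose at all.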